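The source may hold more compounds than are shown below. What is called first, only, known or untested is meant among the compounds shown, and "the series" means these compounds.

Measured so far in a functional assay on A549 cells (Homo sapiens) for cytotoxicity, read by MTT assay, with a stated time of 24 h; a lower number here means a stronger inhibitor, a higher number a weaker inhibitor:
compound 1 `Cc1ccc2oc(-c3ccc(NC(=O)CN4CCN(CCN(C)C)CC4)cc3)nc2c1` gives 3660 nM
compound 2 `CN(C)CCN1CCN(CC(=O)Nc2ccc(-c3nc4ccccc4o3)cc2)CC1` gives 18700 nM
compound 3 `CN(C)CCN1CCN(CC(=O)Nc2ccc(-c3nc4cc(F)ccc4o3)cc2)CC1` gives 16600 nM

Compound 3 holds the second highest number of the three; its value and that of compound 2 lie within the scatter of each other, see a 1.1-fold lower number from compound 2 to compound 3 (0.05 log units; within the scatter), while compound 1 sits clearly apart, see a 4.5-fold higher number from compound 1 to compound 3 (0.66 log units; beyond the scatter). Compound 4 `Cc1cc(-c2nc3cc(F)ccc3o2)ccc1NC(=O)CN1CCN(CCN(C)C)CC1` differs from compound 3 by methyl in place of hydrogen on an aromatic carbon. For the measured compounds named here, the only methyl steps seen so far are a 5.1-fold higher number from compound 1 to compound 2 (0.71 log units; beyond the scatter) and a 4.5-fold higher number from compound 1 to compound 3 (0.66 log units; beyond the scatter), both on the core of compound 1 rather than on the six-membered aromatic ring of carbon only, so they bear only loosely on this change; in both, the methyl compound carried the lower number. Compound 4 is therefore expected to come in somewhat lower than compound 3, a 1.8-fold lower number from compound 3 to compound 4 (0.27 log units; within the scatter), although a step within the scatter would not surprise. The estimate for compound 4 is 9000 nM, with a range from 3500 nM to 25000 nM.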

Compound 4, half-maximal inhibitory concentration: 7370 nM
Compound 4: the middle estimate sits 1.2-fold (0.09 log units) above what was measured; low and high end bracket the measured number.
By their numbers in this assay, from the lowest: compounds 1 and 4 (each within the scatter of the next); then compounds 3 and 2 (each within the scatter of the next).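

In this assay, methyl in place of hydrogen on the six-membered aromatic ring of carbon only, ortho to a large group, gives a 2.3-fold lower number from compound 3 to compound 4 (0.35 log units; beyond the scatter). The earlier methyl steps lay elsewhere in the molecule, so the lower number with methyl now appears at a second place, and no compound shown goes against this direction. The two steps agree in size as well as in direction: the same change on two cores in this assay, a 5.1-fold higher number (0.71 log units; beyond the scatter) from compound 1 to compound 2 and a 2.3-fold higher number (0.35 log units; beyond the scatter) from compound 4 to compound 3, 2.3-fold (0.36 log units) apart, within the scatter of two such steps

Open, going by these compounds, is whether ethyl, methoxy or chloro at this position would keep the lower number. A single step also leaves open whether methyl here would give the same result without the fluoro group.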